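Compound 2 at the limit, compound 3 still open

The compounds below may be only part of what the source reports. "The series", "measured", "known", "first", "only" and "open" are said of these compounds alone.

In an ADME assay on BJ cells (Homo sapiens) for cytotoxicity, with a stated time of 72 h (on this read-out higher numbers stand for an effect only at larger amounts of compound and lower numbers for an effect already at smaller amounts), compound 1 (`C=C[C@@](C)(/C=C/c1ccc(OS(=O)(=O)C(F)(F)F)cc1)CCC=C(C)C`) gives > 36600 nM as a limit of the assay and not a number. Compound 2 (`C=C[C@@](C)(/C=C/c1ccc(Nc2ccc(F)cc2)cc1)CCC=C(C)C`) likewise gives > 36600 nM as a limit, so it has no exact position on this scale. Going by the values given here, the only measured step is a step that the two limits leave unreadable from compound 1 to compound 2 and it offers no size to carry forward, as both compounds stand at the same ceiling (the limit of > 36600 nM in this assay, at which 2 of the 2 values shown sit). Compound 3 (`C=C[C@@](C)(/C=C/c1ccc(Nc2ccc(Cl)c(F)c2)cc1)CCC=C(C)C`) carries 4-chloro-3-fluorophenyl in place of 4-fluorophenyl on a nitrogen on an aromatic ring. With no readable step behind it, no clear move in either direction is expected in this assay and a result at the limit again seems likely. Compound 3 is estimated at 36600 nM with an expected range from 15000 nM to 50000 nM as its likely span. That is an expected a number no higher from compound 2 to compound 3 (the limit leaves the size open) and no more.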

Compound 3, half-maximal effective concentration: > 36600 nM
Compound 3 ended at the assay's limit; the forecaster's own chance of this, stated with the estimate: 70%; the middle value lies on the limit itself.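

No new step can be read between compound 1, compound 2 and compound 3 in this assay, as each value is a limit and not a number: the limit of > 36600 nM in this assay, at which 3 of the 3 values shown sit.

The compounds shown leave open where each of the three truly lies on this scale, and whether either change alters the read-out at all.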